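From 3-fluorophenyl to 2-fluorophenyl in compound 4

The source may report more compounds than this note shows. Statements on the series, on what has been measured and on what is new or still open speak of the compounds shown alone.

In a functional assay on HL-60 cells (Homo sapiens) for inhibition, read by MTT assay, with a stated time of 72 h (on this read-out lower numbers stand for stronger inhibition and higher numbers for weaker inhibition), compound 3 (`CCc1nc(-c2cccc(F)c2)c(C(=O)N2CCN(c3cccc(OC)c3)CC2)o1`) gives 201 nM and cannot be told apart from compound 1 (`CCc1nc(-c2ccccc2F)c(C(=O)N2CCN(c3cccc(Cl)c3)CC2)o1`) at 139 nM on these numbers. Compound 2 (`COc1cccc(N2CCN(C(=O)c3oc(C)nc3-c3ccccc3F)CC2)c1`) at 56.1 nM lies lower than compound 3 by more than the scatter. Compound 4 (`CCc1nc(-c2ccccc2F)c(C(=O)N2CCN(c3cccc(OC)c3)CC2)o1`) has 2-fluorophenyl in place of 3-fluorophenyl on an aromatic carbon. Within the data shown here, no measured pair isolates this change. Compound 1 (139 nM) and compound 2 (56.1 nM) both carry 2-fluorophenyl but differ from compound 4 elsewhere, so only a modest fall near the edge of the scatter is expected in this assay for this change. The estimated move is a 2.0-fold lower number from compound 3 to compound 4 (0.30 log units; within the scatter) and remains uncertain. Compound 4 is expected at 100 nM (estimated range 40 nM to 230 nM).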

Compound 4, half-maximal inhibitory concentration: 607 nM
Compound 4: middle estimate off by 6.1-fold (0.78 log units), on the low side; measured number outside the range, above it.
By their numbers in this assay, from the lowest: compound 2; then compounds 1 and 3 (each within the scatter of the next); then compound 4.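

In this assay, among these compounds, 2-fluorophenyl in place of 3-fluorophenyl gives a 3.0-fold higher number from compound 3 to compound 4 (0.48 log units; beyond the scatter) and so raises the number at this ring carbon, which no earlier pair could show. Compound 4 also shows that 2-fluorophenyl alone does not secure a low number: with that group unchanged, methyl in place of hydrogen on the saturated chain carbon gives an 11-fold higher number from compound 2 to compound 4 (1.03 log units; beyond the scatter) and methoxy in place of chloro gives a 4.4-fold higher number from compound 1 to compound 4 (0.64 log units; beyond the scatter) on the other aromatic ring.

Going by these compounds, how an unsubstituted phenyl or 4-fluorophenyl would compare at this place stays open. Nothing measured here gives a reason for these steps.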